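Replacing a Hydroxyalkynyl Chain with a Biphenyl Group

The source may report more compounds than this note shows. Statements on the series, on what has been measured and on what is new or still open speak of the compounds shown alone.

Compound 3 `Cn1cncc1C(OCc1ccc(C#N)cc1C#CCCCCO)c1ccc(C#N)cc1` stands lowest of the three measured compounds in a functional assay on NIH3T3 cells (Mus musculus) (a higher number here means that more compound is needed for the effect, a lower number that less compound is needed), at 20.9 nM. Compound 1 `Cn1cncc1C(OCc1ccc(C#N)cc1C#CC(C)(C)C)c1ccc(C#N)cc1` gives 76.9 nM in this assay, and compound 2 `Cn1cncc1C(OCc1ccc(C#N)cc1-c1ccccc1)c1ccc(C#N)cc1` gives 140 nM. The steps of a 3.7-fold lower number from compound 1 to compound 3 (0.57 log units; beyond the scatter) and a 6.7-fold lower number from compound 2 to compound 3 (0.83 log units; beyond the scatter) both set compound 3 apart, whereas a 1.8-fold higher number from compound 1 to compound 2 (0.26 log units; within the scatter) does not.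

Compound 4 `Cn1cncc1C(OCc1ccc(C#N)cc1-c1ccc(-c2ccccc2)cc1)c1ccc(C#N)cc1` differs from compound 3 in one place: 4-phenylphenyl in place of 6-hydroxyhex-1-yn-1-yl on an aromatic carbon. The measured step that bears most directly on this change is the reverse one, a 6.7-fold lower number from compound 2 to compound 3 (0.83 log units; beyond the scatter), in which a phenyl gave way to the 6-hydroxyhex-1-yn-1-yl group. Read in the opposite direction, an aromatic group entering in place of the hydroxy-bearing chain points toward a higher number in this assay. Among the compounds with values here, compound 2, carrying a phenyl on an aromatic carbon of the shared core, gives 140 nM; the 4-phenylphenyl entering in compound 4 is larger than phenyl, and no measured compound shows how much that extension matters. The expected step is a 9.6-fold higher number from compound 3 to compound 4 (0.98 log units; beyond the scatter). Compound 4 is therefore estimated at 200 nM, with a range from 60 nM to 700 nM.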

Compound 4, half-maximal effective concentration: < 0.1 nM
Compound 4 ended at the assay's limit; the forecaster's own chance of this, stated with the estimate: 5%; middle value at least 2000-fold (3.30 log units) from the limit.
By their numbers in this assay, from the lowest: compound 3; then compounds 1 and 2 (each within the scatter of the next). At a limit, below all of these: compound 4.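

Compound 4 stands at a limit of this assay, so its value is not an exact number: the limit of < 0.1 nM in this assay, at which 1 of the 4 values shown sits.

Within the data shown here, a single phenyl in place of hydrogen on the aromatic group at this position brings an at least 1400-fold lower number from compound 2 to compound 4 (3.14 log units; beyond the scatter), so a one-ring and a two-ring aromatic group give very different results here, which the earlier compounds could not show. The 4-phenylphenyl group also stands far from both alkynyl chains, with an at least 760-fold lower number from compound 1 to compound 4 (2.88 log units; beyond the scatter) and an at least 200-fold lower number from compound 3 to compound 4 (2.32 log units; beyond the scatter), and it reaches the limit with 0 hydrogen-bond donors, whereas the lowest earlier number belonged to the chain ending in a hydroxy group.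

On these data alone, how far the true value of compound 4 lies past its limit remains open. Also open, as far as these compounds go, is whether a 3-phenylphenyl, a naphthyl or a 4-aminophenyl group would behave like 4-phenylphenyl.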